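Chloro to fluoro on the aryl ring of compound 2

The source may report more compounds than this note shows. Statements on the series, on what has been measured and on what is new or still open speak of the compounds shown alone.

Three chalcone-type compounds with a shared core have been measured in a functional assay on MDA-MB-435 cells (Homo sapiens) for inhibition; on this read-out higher numbers stand for weaker inhibition and lower numbers for stronger inhibition. Compound 1 `O=C(/C=C/c1ccc(B(O)O)cc1)c1ccc[nH]1` gives 15000 nM. Compound 2 `O=C(/C=C/c1ccc(F)c(Cl)c1)c1ccc(B(O)O)cc1` gives 16000 nM, a number that differs from that of compound 1 by less than the usual scatter, so the two cannot be told apart. Compound 3 `O=C(/C=C/c1ccc(I)cc1)c1ccc(O)cc1` gives 4500 nM, and its gap to compound 2 lies beyond the scatter, with compound 3 on the lower side. No pair among these three differs in one place only, so no single-point step is available.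

Compound 4 `O=C(/C=C/c1ccc(F)c(F)c1)c1ccc(B(O)O)cc1` is not yet measured. It differs from compound 2 in one place: fluoro in place of chloro on an aromatic carbon. The exchange keeps the count of heavy atoms, donors, acceptors and charge unchanged. Among the measured compounds shown here, with no matching step among the measured compounds to draw on, the change is expected to move this assay little, if at all, beyond the scatter, as a 1.1-fold higher number from compound 2 to compound 4 (0.05 log units; within the scatter). Compound 4 is therefore estimated at 18000 nM, with a range from 8000 nM to 40000 nM.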

Compound 4, half-maximal inhibitory concentration: 8800 nM
Compound 4: the middle estimate sits 2.0-fold (0.31 log units) above what was measured; low and high end bracket the measured number.
By their numbers in this assay, from the lowest: compounds 3, 4, 1 and 2 (each within the scatter of the next, the first and the last beyond it).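

In this assay, among the compounds shown here, the only single-place step so far, fluoro in place of chloro on an aromatic carbon, gives a 1.8-fold lower number from compound 2 to compound 4 (0.26 log units; within the scatter) and so compounds 2 and 4 cannot be told apart. This position, ortho to a fluoro group and meta to a large group, therefore accepts either of these two groups without a readable change in this read-out, though this single exchange is all that speaks for it. Nothing at hand explains the step or gives a measured property of either group.

Going by these compounds, whether a bromo group, an amine or a nitrile at this position would move the number beyond the scatter remains open. Also open, on these data alone, is how compound 4 would respond if a carboxylic acid took the place of its boronic acid group.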